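The source may hold more compounds than are shown below. What is called first, only, known or untested is meant among the compounds shown, and "the series" means these compounds.

Notes on the series. Compound 1, `O=C(O)c1cccc([C@H]2C[C@@H](c3ccc(OCc4c(-c5c(Cl)cccc5Cl)noc4C4CC4)cc3Cl)C2)c1`, gives 99% in an assay on isolated protein for agonist activity at Bile acid receptor (Homo sapiens), read by FRET; a higher number here means a larger maximal response, a lower number a smaller maximal response. Compound 2, `O=C(O)c1cccc([C@H]2C[C@](OCCO)(c3ccc(OCc4c(-c5c(Cl)cccc5Cl)noc4C4CC4)cc3Cl)C2)c1`, gives 97% in the same assay and stands lowest of the two numbers, with compound 1 nearest at a number 2 percentage points lower from compound 1 to compound 2 (within the scatter). Compound 3, `O=C(O)c1cccc([C@H]2C[C@](O)(c3ccc(OCc4c(-c5c(Cl)cccc5Cl)noc4C4CC4)cc3Cl)C2)c1`, differs from compound 2 by hydrogen in place of 2-hydroxyethyl on an oxygen on a saturated carbon. Within the data shown here, the only measured step that bears on this position is the one from hydrogen to 2-hydroxyethoxy, which stayed within the scatter, so no step beyond the scatter is expected in this assay. Compound 3 is therefore estimated at 97%, range 87% to 105%, meaning an expected step of no change at the digits printed from compound 2 to compound 3 (within the scatter).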

Compound 3, largest response reached (reported as efficacy), in percent of the reference or control that the assay uses: 100%
The estimate for compound 3 lay 3 percentage points below the measured number; measured number inside the range.
By their numbers in this assay, from the lowest: compounds 2, 1 and 3 (each within the scatter of the next).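

In this assay, hydroxy in place of hydrogen on the saturated ring carbon gives a number 1 percentage points higher from compound 1 to compound 3 (within the scatter) and hydrogen in place of 2-hydroxyethyl on the oxygen gives a number 3 percentage points higher from compound 2 to compound 3 (within the scatter), so this read-out does not separate hydrogen, hydroxy and 2-hydroxyethoxy at this carbon. The 2-hydroxyethyl chain is therefore not required for the full maximal response seen across these three compounds. Nothing available explains this flat result. Still open, going by these compounds, is whether an amine or a carboxylic acid on this carbon would match these numbers. A chain longer than 2-hydroxyethyl on the oxygen also remains untested in the compounds shown.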